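Swapping a Nitrile for a Pyrazole on a Dopamine Ligand

A few compounds are considered here, and "the series" means these few. Any claim that something is new, unique, unknown or untested is made for them only; others in the source may bear on it.

Of the compounds shown here, three have been measured in an assay on CHO cells for displacement of a labelled ligand from D(4) dopamine receptor (Homo sapiens); on this read-out higher numbers stand for weaker inhibition and lower numbers for stronger inhibition. Compound 1 `COc1ccccc1N1CCN(Cc2cn3cc(I)ccc3n2)CC1` gives 0.33 nM, compound 2 `Clc1ccc(N2CCN(Cc3cn4cc(Br)ccc4n3)CC2)cc1Cl` gives 0.99 nM, and compound 3 `COc1ccccc1N1CCN(Cc2cn3cc(C)cc(C#N)c3n2)CC1` gives 1.3 nM. Compound 3 thus carries the highest of the three numbers; its value and that of compound 2 fall within the usual scatter of each other, so no order between them can be claimed, whereas compound 1 lies beyond the scatter from compound 3 and binds more strongly.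

Compound 4 `COc1ccccc1N1CCN(Cc2cn3cc(C)cc(-n4cccn4)c3n2)CC1` has not yet been measured. It differs from compound 3 in one place: 1H-pyrazol-1-yl in place of cyano on an aromatic carbon. Among the compounds with values here, no pair of measured compounds shows this same change, so there is no measured step to lean on; the expectation rests on compound 3 alone at 1.3 nM. A small weakening is expected, the step being estimated at a 1.7-fold higher number from compound 3 to compound 4 (0.23 log units; within the scatter), most likely staying inside the scatter. Compound 4 is therefore expected to give about 2.2 nM in this assay, within a range of 0.6 nM to 8 nM.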

Compound 4, inhibition constant: 1.6 nM
Beside the measured number, compound 4's estimate is 1.4-fold (0.14 log units) above it, and the stated range covers the measured number.
By their numbers in this assay, from the lowest: compound 1; then compounds 2, 3 and 4 (each within the scatter of the next).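

In this assay, putting 1H-pyrazol-1-yl in place of cyano on this aromatic carbon, ortho to a fused ring, gives a 1.2-fold higher number from compound 3 to compound 4 (0.09 log units; within the scatter). Within the data shown here, this pair therefore shows what the earlier compounds could not: at this position, a group of 5 heavy atoms containing a five-membered aromatic ring can stand where a cyano group of 2 heavy atoms stood, with no difference that can be told from the scatter. No measurement here explains why the two groups read alike.

The compounds shown leave open how an amine, a carboxylic acid or a longer chain on this same carbon would read in this assay. Among these compounds, with only one pair, they also leave open whether this swap would give a similar result on another core.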